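The source may report more compounds than this note shows. Statements on the series, on what has been measured and on what is new or still open speak of the compounds shown alone.

Measured compounds:
compound 1 `Cc1cccc2sc(NC(=O)CCN3CCN(C(C)C)CC3)nc12`: 1300 nM
compound 2 `Cc1cccc2sc(NC(=O)CCN3CCN(CC4CCCO4)CC3)nc12`: 109 nM

Both compounds share one core and differ only in the group on the amine nitrogen in the ring. In an assay on membranes from brain for displacement of a labelled ligand from Sigma non-opioid intracellular receptor 1 (Cavia porcellus), read by scintillation counting, with a stated time of 120 min (a higher number here means a weaker inhibitor, a lower number a stronger inhibitor), compound 1 gives 1300 nM, and compound 2 gives 109 nM in this assay. Compound 2 thus holds the lowest of the two numbers, with compound 1 as its nearest neighbour, and the step of a 12-fold lower number from compound 1 to compound 2 (1.08 log units; beyond the scatter) shows that a change at this position can move the number by a large amount.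

Compound 3 `Cc1cccc2sc(NC(=O)CCN3CCN(C4CCCCC4)CC3)nc12` is not yet measured. It differs from compound 2 in one place: cyclohexyl in place of (oxolan-2-yl)methyl on an amine nitrogen in a ring. For the measured compounds named here, the only measured step that bears on this position is a 12-fold lower number from compound 1 to compound 2 (1.08 log units; beyond the scatter), where a branched chain gave way to a chain that carries a five-membered ring with one oxygen. Cyclohexyl matches neither of those two groups, so the direction of the new step is uncertain. Because the swing seen in a 12-fold lower number from compound 1 to compound 2 (1.08 log units; beyond the scatter) was large, a change beyond the scatter is expected, most likely toward a higher number than compound 2, giving an estimated step of a 2.3-fold higher number from compound 2 to compound 3 (0.36 log units; beyond the scatter). Compound 3 is thus expected to give about 250 nM in this assay, within a range of 60 nM to 1000 nM.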

Compound 3, inhibition constant: 24 nM
The estimate for compound 3 lay 10-fold (1.02 log units) above the measured number; the whole stated range lies above it.
By their numbers in this assay, from the lowest: compound 3; then compound 2; then compound 1.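

For the compounds shown here, the order at this position is now clear: the step to cyclohexyl, a 4.5-fold lower number from compound 2 to compound 3 (0.66 log units; beyond the scatter), shows that the group on the amine nitrogen in the ring need not carry an oxygen for the number in this assay to fall, and the lowest number so far belongs to a six-membered ring of carbon only. The step of a 54-fold lower number from compound 1 to compound 3 (1.73 log units; beyond the scatter) adds that an all-carbon group is not enough by itself, since isopropyl also lacks oxygen yet stands highest of the three, so compound 1 goes against any reading that ties the lower numbers simply to the absence of oxygen. Nothing measured here accounts for these differences.

The change from compound 2 to compound 3 alters the ring size, the oxygen and the methyl link all at once, so these compounds cannot say which of them matters. Going by these compounds, it also remains open how a cyclopentyl group, a cyclohexylmethyl group or a phenyl ring on this nitrogen would compare with cyclohexyl.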